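Replacing the terminal biphenyl of compound 2 with a benzodioxinyl group

The compounds below may be only part of what the source reports. "The series", "measured", "known", "first", "only" and "open" are said of these compounds alone.

Compound 1 `CC(C)N(Cc1cccc(OCCCCCC(=O)O)c1)C(=O)c1ccc(-c2cccc(-c3ccccc3)c2)cc1`: in an ADME assay on HEK293 cells (Homo sapiens) for cytotoxicity, read by CellTiter-Glo and resazurin assay, with a stated time of 72 h (on this read-out higher numbers stand for an effect only at larger amounts of compound and lower numbers for an effect already at smaller amounts), compound 1 gives > 26000 nM, which is a limit of this assay and not a number.
Compound 2 `CCOC(=O)CCCCCOc1cccc(CN(C(=O)c2ccc(-c3cccc(-c4ccccc4)c3)cc2)C(C)C)c1`: compound 2 gives > 26000 nM, again a limit.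
Compound 3 `CCOC(=O)CCCCCOc1cccc(CN(C(=O)c2ccc(-c3cccc(Oc4ccccc4)c3)cc2)C(C)C)c1`: compound 3 gives > 19600 nM, likewise a limit.

Compound 2 thus sits at the limit of > 26000 nM in this assay, at which 2 of the 3 values shown sit, and no rank among the three can be read from these limits. Compound 4 `CCOC(=O)CCCCCOc1cccc(CN(C(=O)c2ccc(-c3ccc4c(c3)OCCO4)cc2)C(C)C)c1` differs from compound 2 by 2,3-dihydro-1,4-benzodioxin-6-yl in place of 3-phenylphenyl on an aromatic carbon. The two measured steps that bear on this change, a step that the two limits leave unreadable from compound 1 to compound 2 and a step that the two limits leave unreadable from compound 2 to compound 3, are both unreadable because each end is only a limit. Nothing measured here therefore points to a step beyond the scatter, and the account expects compound 4 to remain near the limits seen so far, with a step that the limit leaves unreadable from compound 2 to compound 4 expected as no change. The estimate for compound 4 is 30000 nM, between 10000 nM and 100000 nM.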

Compound 4, half-maximal effective concentration: > 24400 nM
Compound 4: only a limit was reported (the forecaster's own chance of this, stated with the estimate: 80%); the middle value does not contradict the limit.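

Going by these compounds alone, compound 4, like compound 2, is reported only as a limit in this assay, and no step between them can be read. The compounds shown leave open at what concentration any of them would reach a half-maximal effect in this assay.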